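Working notes: aryl exchange on the carbonyl carbon

The source may report more compounds than this note shows. Statements on the series, on what has been measured and on what is new or still open speak of the compounds shown alone.

Compound 1 `COc1cc(-c2cc(/C=C/C(=O)c3ccc(Cl)c(Cl)c3)[nH]n2)cc(OC)c1OC`: 95%
Compound 2 `COc1ccc(-c2cc(/C=C/C(=O)c3ccc(N)cc3)[nH]n2)cc1OC`: 92%

Both numbers come from a functional assay on BT-549 cells (Homo sapiens) for cytotoxicity, read by sulforhodamine B assay, with a stated time of 48 h, tested at 0.1 uM; a lower number here means a stronger effect, a higher number a weaker effect of the compound at the concentration tested. Compound 1 stands at the top of the two, though the gap to compound 2 is within the scatter, so the pair reads as alike and weak at this concentration. Compound 3 `COc1ccc(C(=O)/C=C/c2cc(-c3cc(OC)c(OC)c(OC)c3)n[nH]2)cc1OC` is unmeasured. It differs from compound 1 in one place: 3,4-dimethoxyphenyl in place of 3,4-dichlorophenyl on a carbonyl carbon. Within the data shown here, no step between measured compounds covers this change, and the two numbers give no sign of a shift beyond the scatter, so the step of a number 2 percentage points lower from compound 1 to compound 3 (within the scatter) is expected to be small and of no set direction. For compound 3 the estimate in this assay is 93%, with a range from 80% to 102%.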

Compound 3, a percentage reported as activity, at one concentration (the size of the read-out at that concentration, not a potency): 90%
Beside the measured number, compound 3's estimate is 3 percentage points above it; the measured number falls inside the stated range.
By their numbers in this assay, from the lowest: compounds 3, 2 and 1 (each within the scatter of the next).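

Among these compounds, the exchange of 3,4-dichlorophenyl for 3,4-dimethoxyphenyl on a carbonyl carbon gives the first one-place step: in this assay it is a number 5 percentage points lower from compound 1 to compound 3 (within the scatter). At this position, then, the two aryl groups read as alike at the concentration tested, which the earlier pair, differing in more than one place, could not show. No measurement on hand bears on the reason for this result.

From the compounds shown here alone, whether any group on this carbonyl carbon moves the read-out beyond the scatter stays open. A carboxylic acid or a morpholine on the aryl ring would test this.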